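A few compounds are considered here, and "the series" means these few. Any claim that something is new, unique, unknown or untested is made for them only; others in the source may bear on it.

Three compounds of the series have been run in an ADME assay on NIH3T3 cells (Mus musculus) for cytotoxicity, read by MTT assay, with a stated time of 24 h; on this read-out higher numbers stand for weaker inhibition and lower numbers for stronger inhibition. Compound 1 `O=C(CSc1nnc(-c2ccncc2)o1)N/N=C/c1ccccc1` gives 167000 nM in this assay. Compound 2 `O=C(CSc1nnc(-c2ccncc2)o1)N/N=C/c1ccc(F)cc1` gives 170000 nM. Compound 3 `O=C(CSc1nnc(-c2ccncc2)o1)N/N=C/c1cccc(F)c1` gives 205000 nM, the highest of the three numbers, though its gaps to compound 2 and to compound 1 both sit within the scatter. The steps among them were a 1.0-fold higher number from compound 1 to compound 2 (0.01 log units; within the scatter), a 1.2-fold higher number from compound 1 to compound 3 (0.09 log units; within the scatter) and a 1.2-fold higher number from compound 2 to compound 3 (0.08 log units; within the scatter), none of them beyond the scatter.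

Compound 4 `O=C(CSc1nnc(-c2ccncc2)o1)N/N=C/c1ccccc1[N+](=O)[O-]` has not been measured. The change is 2-nitrophenyl in place of 3-fluorophenyl on a carbon with a double bond to nitrogen. Within the data shown here, the steps that bear on it are a 1.2-fold higher number from compound 2 to compound 3 (0.08 log units; within the scatter), an exchange of one fluorophenyl for the other, and a 1.2-fold higher number from compound 1 to compound 3 (0.09 log units; within the scatter), the addition of a fluoro to the bare phenyl; both stayed within the scatter. The entering group has not been tried anywhere in the series, so no step beyond the scatter is expected in this assay. Compound 4 is therefore estimated at 190000 nM, with a range from 100000 nM to 360000 nM. That estimate means an expected step of a 1.1-fold lower number from compound 3 to compound 4 (0.03 log units; within the scatter), within the scatter.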

Compound 4, half-maximal inhibitory concentration: 214000 nM
Beside the measured number, compound 4's estimate is 1.1-fold (0.05 log units) below it; measured number inside the range.
By their numbers in this assay, from the lowest: compounds 1, 2, 3 and 4 (each within the scatter of the next).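

Among these compounds, at the carbon with a double bond to nitrogen, the exchange of 3-fluorophenyl for 2-nitrophenyl, the first entering group other than a fluorophenyl, gives in this assay only a 1.0-fold higher number from compound 3 to compound 4 (0.02 log units; within the scatter). The same holds against the other two compounds, with a 1.3-fold higher number from compound 2 to compound 4 (0.10 log units; within the scatter) and a 1.3-fold higher number from compound 1 to compound 4 (0.11 log units; within the scatter), so a nitro at this phenyl, like a fluoro, has produced no step beyond the scatter, and the four compounds remain unordered in this assay. No measurement at hand gives a reason for this flat result.

Going by these compounds, whether an amine or a carboxylic acid on this phenyl, or a longer chain in its place, would move the number beyond the scatter stays open. The compounds shown also leave open whether any change to the shared core would do so.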